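A few compounds are considered here, and "the series" means these few. Any claim that something is new, unique, unknown or untested is made for them only; others in the source may bear on it.

Series notes. In an assay for inhibition of Fatty-acid amide hydrolase 1 (Rattus norvegicus) (on this read-out higher numbers stand for weaker inhibition and lower numbers for stronger inhibition), compound 1 `O=C(CCc1ccc(-c2ccccc2)cc1)c1ncc(-c2ccncc2)o1` gives 2.3 nM, the lowest of the three numbers. Compound 2 `COC(=O)c1cccc(-c2cnc(C(=O)CCc3ccc(OC4CCN(C(=O)OC(C)(C)C)CC4)cc3)o2)n1` gives 32 nM in this assay, beyond the scatter from compound 1; compound 3 `O=C(O)c1cccc(-c2cnc(C(O)CCc3ccc(-c4ccccc4)cc3)o2)n1` gives 1100 nM, further still. For the measured compounds named here, no two measured compounds differ in one place only, so no single step is isolated here. Compound 4 `O=C(O)c1cc(-c2cnc(C(=O)CCc3ccc(-c4ccccc4)cc3)o2)ccn1` is not yet measured; it differs from compound 1 by carboxy in place of hydrogen on an aromatic carbon. Compound 3 also carries a carboxy on a six-membered aromatic ring with 1 nitrogen and gives 1100 nM, but it differs from compound 1 in more than one place. For compound 4 a weakening beyond the scatter is expected, a 13-fold higher number from compound 1 to compound 4 (1.12 log units; beyond the scatter). Compound 4 is estimated at 30 nM, within 5 nM to 200 nM.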

Compound 4, inhibition constant: 50 nM
Estimate against measurement, compound 4: 1.7-fold (0.22 log units) below; the range from low to high includes it.
By their numbers in this assay, from the lowest: compound 1; then compounds 2 and 4 (each within the scatter of the next); then compound 3.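

In this assay, for the compounds shown here, putting carboxy on the aromatic carbon next to the ring nitrogen gives the first isolated single change, and it is a large one: a 22-fold higher number from compound 1 to compound 4 (1.34 log units; beyond the scatter) as pyridin-4-yl becomes 2-carboxypyridin-4-yl. Even so, compound 4 still gives 50 nM with the rest of compound 1 unchanged. No evidence at hand bears on the size of this step.

Open, from the compounds shown here alone, is whether a methyl ester, an amide or an amine at this place would give a similar number. Also open, going by these compounds, is how carboxy would read on other carbons of this ring.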